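Swapping a fluorophenyl for a benzyl on a pyrazole-like core

The source may hold more compounds than are shown below. What is called first, only, known or untested is meant among the compounds shown, and "the series" means these compounds.

Of the compounds shown here, two sharing a core have been tested in an ADME assay on Huh-7 cells (Homo sapiens) for cytotoxicity; on this read-out higher numbers stand for lower toxicity in this test and lower numbers for higher toxicity in this test. Compound 1 `Cc1ccccc1-c1nn(-c2ccc(F)cc2)cc1CNCCN1CCN(C)CC1` reaches only the limit of this assay, giving > 20000 nM; this is a boundary of the measurement, not a number, and it is where the limit of > 20000 nM in this assay, at which 1 of the 2 values shown sits, sits. Compound 2 `CN1CCN(CCCNCc2cn(-c3ccc(C(F)(F)F)cc3)nc2-c2ccc(Cl)cc2)CC1` differs from compound 1 in several places at once; in this assay compound 2 gives 2500 nM.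

Compound 3 `Cc1ccccc1-c1nn(Cc2ccccc2)cc1CNCCN1CCN(C)CC1` has not yet been measured in this assay. It differs from compound 1 by one change: benzyl in place of 4-fluorophenyl on an aromatic nitrogen. Going by the values given here, no step between measured compounds isolates this change, so the expectation rests on compound 1 alone. The expected shift is a number no higher from compound 1 to compound 3 (the limit leaves the size open), that is, none beyond the usual scatter. Compound 3 is therefore estimated at 20000 nM in this assay, with a range from 8000 nM to 40000 nM, and a fair chance that only a limit is reported again.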

Compound 3, half-maximal cytotoxic concentration: > 20000 nM
Compound 3: no number, only a limit (the forecaster's own chance of this, stated with the estimate: 50%); the middle value lies on the limit itself.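

In this assay, compound 3 gives only a limit, as compound 1 does, so no step can be read between compound 1 and compound 3: the limit of > 20000 nM in this assay, at which 2 of the 3 values shown sit.

On these data alone, whether benzyl and 4-fluorophenyl on this aromatic nitrogen differ at all in this assay stays open.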